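The source may hold more compounds than are shown below. What is called first, only, known or untested is meant among the compounds shown, and "the series" means these compounds.

In a functional assay on HEK293 cells for agonist activity at Free fatty acid receptor 1 (Homo sapiens), read by fluorescence and calcium flux (on this read-out higher numbers stand for an effect only at larger amounts of compound and lower numbers for an effect already at smaller amounts), compound 3 `CC#CC(CC(=O)O)c1ccc(OCc2ccc(C(=O)N3CCN(c4ccc(Cl)cc4)CC3)s2)cc1` gives 133 nM, the lowest of the three numbers shown, though the gaps to the other two stay within the scatter. Compound 1 `CC#CC(CC(=O)O)c1ccc(OCc2ccc(C(=O)N3CCN(c4ccc(C)cc4)CC3)s2)cc1` gives 211 nM and compound 2 `CC#CC(CC(=O)O)c1ccc(OCc2ccc(C(=O)N3CCN(c4ccc([N+](=O)[O-])cc4)CC3)s2)cc1` gives 231 nM; the steps of a 1.6-fold lower number from compound 1 to compound 3 (0.20 log units; within the scatter) and a 1.7-fold lower number from compound 2 to compound 3 (0.24 log units; within the scatter) are both small, as is a 1.1-fold higher number from compound 1 to compound 2 (0.04 log units; within the scatter). All three share one core and differ only in the group on the amine nitrogen in a ring, and on this evidence methyl, nitro and chloro on that aromatic carbon give much the same result. Compound 4 `CC#CC(CC(=O)O)c1ccc(OCc2ccc(C(=O)N3CCN(c4ccccc4[N+](=O)[O-])CC3)s2)cc1` takes the step (2-nitrophenyl in place of 4-chlorophenyl on an amine nitrogen in a ring). For the measured compounds named here, the measured steps that bear on it, a 1.7-fold lower number from compound 2 to compound 3 (0.24 log units; within the scatter) and a 1.1-fold higher number from compound 1 to compound 2 (0.04 log units; within the scatter), were both within the scatter, and no measured pair holds 2-nitrophenyl, so nothing here points to a large move in either direction. The step of a 1.7-fold higher number from compound 3 to compound 4 (0.22 log units; within the scatter) is therefore expected to be small, at most a modest rise in the number. Compound 4 is estimated at 220 nM, with a range from 90 nM to 550 nM.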

Compound 4, half-maximal effective concentration: 94 nM
Estimate against measurement, compound 4: 2.3-fold (0.37 log units) above; low and high end bracket the measured number.
By their numbers in this assay, from the lowest: compounds 4, 3, 1 and 2 (each within the scatter of the next, the first and the last beyond it).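

Unlike the steps among compound 1, compound 2 and compound 3, two steps at this position now go beyond the scatter: 2-nitrophenyl in place of 4-nitrophenyl gives a 2.5-fold lower number from compound 2 to compound 4 (0.39 log units; beyond the scatter) and 2-nitrophenyl in place of 4-methylphenyl gives a 2.2-fold lower number from compound 1 to compound 4 (0.35 log units; beyond the scatter) as modest moves. The first of these keeps the nitro group and changes only where it sits on the phenyl ring, so that change alone is enough to move the number. Against 4-chlorophenyl the same group gives only a 1.4-fold lower number from compound 3 to compound 4 (0.15 log units; within the scatter) and that pair stays level within the scatter.

On these data alone, whether 2-chlorophenyl, 2-methylphenyl or 2-aminophenyl would behave like 2-nitrophenyl remains open, so the step cannot yet be tied to the nitro group or to any group at that place. Nothing available here accounts for these steps.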